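The source may hold more compounds than are shown below. What is called first, only, known or untested is meant among the compounds shown, and "the series" means these compounds.

Measured so far:
- compound 1 `Clc1cccc(Cl)c1Cc1nnc(Nc2ccc(COCc3ccccn3)cc2)o1`: > 100000 nM
- compound 2 `Fc1cccc(F)c1Cc1cnc(Nc2ccc(Oc3cccnc3)c(Cl)c2)o1`: 16000 nM
- compound 3 `Fc1cccc(F)c1Cc1cnc(Nc2ccc(Oc3ccncc3)c(Cl)c2)o1`: 21000 nM

All three were tested in an ADME assay on MT2 cells (Homo sapiens) for cytotoxicity, read by MTT assay; a higher number here means that more compound is tolerated, a lower number that less compound is tolerated. For compound 1 the result is only a limit and not a number, so compound 1 sits at the limit of > 100000 nM in this assay, at which 1 of the 3 values shown sits. Compound 2 gives 16000 nM and compound 3 gives 21000 nM. Within the data shown here, the one measured step, a 1.3-fold higher number from compound 2 to compound 3 (0.12 log units; within the scatter), shows that exchanging one ring for another on that core left the read-out within the scatter.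

Compound 4 `Clc1cccc(Cl)c1Cc1nnc(Nc2ccc(COCc3ccco3)cc2)o1` is built on the core of compound 1, with the change (furan-2-yl in place of pyridin-2-yl on a saturated chain carbon bound to an oxygen on a saturated carbon). Among the measured compounds shown here, no measured step touches this change or this core; the one step available concerns a different core and a different pair of rings, and it stayed within the scatter. There is therefore no ground to expect compound 4 to move beyond the scatter from compound 1, and the expected step is a number no higher from compound 1 to compound 4 (the limit leaves the size open). Compound 4 is estimated at 100000 nM, with a range from 40000 nM to 250000 nM, most likely again reported only as a limit.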

Compound 4, half-maximal cytotoxic concentration: 12000 nM
Beside the measured number, compound 4's estimate is 8.3-fold (0.92 log units) above it; the measured number lies below the stated range.
By their numbers in this assay, from the lowest: compounds 4, 2 and 3 (each within the scatter of the next). At a limit, above all of these: compound 1.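

In this assay the ring at this place matters: furan-2-yl in place of pyridin-2-yl on a saturated chain carbon bound to an oxygen on a saturated carbon gives an at least 8.3-fold lower number from compound 1 to compound 4 (0.92 log units; beyond the scatter) and so lies beyond the scatter, unlike the earlier ring exchange on the other core. Such a result comes from swapping one aromatic ring for another, although each ring has one hetero atom, one hydrogen-bond acceptor and no net charge. The full size of this step stays open because compound 1 has only a limit and not a number: the limit of > 100000 nM in this assay, at which 1 of the 4 values shown sits.

Whether the gain in toxicity belongs to furan-2-yl itself or to the loss of pyridin-2-yl cannot be told from this single pair. As far as these compounds go, how an amine or a carboxylic acid at this place would read also remains open.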